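Removing a Methyl from a Methoxy: Expected Cytotoxicity Outcome

The source may report more compounds than this note shows. Statements on the series, on what has been measured and on what is new or still open speak of the compounds shown alone.

Compounds measured so far in an ADME assay on Vero cells (Chlorocebus sabaeus) for cytotoxicity, read by WST assay; a lower number here means that less compound is tolerated, a higher number that more compound is tolerated:
- compound 1 `COc1cccc(Nc2nc3cc(Cl)ccc3c(=O)[nH]2)c1` gives > 25000 nM
- compound 2 `N#Cc1cccc(Nc2nc3cc(Cl)ccc3c(=O)[nH]2)c1` gives > 25000 nM
- compound 3 `COc1cccc2nc(Nc3cc(F)cc(F)c3)[nH]c(=O)c12` gives > 25000 nM

Each of these three values is a limit of this assay rather than a number. Compound 3 stands at that limit, the same place as the other two: the limit of > 25000 nM in this assay, at which 3 of the 3 values shown sit. Within the data shown here, the only pair that differs in one place, compound 1 and compound 2, gives a step that the two limits leave unreadable from compound 1 to compound 2, so no readable step is available from the measured set.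

Compound 4 `O=c1[nH]c(Nc2cc(F)cc(F)c2)nc2cccc(O)c12` differs from compound 3 as follows: hydrogen in place of methyl on an oxygen on an aromatic ring. Among the measured compounds shown here, none of the measured steps concerns a change of this kind, so nothing here points to a particular direction. With all three measured compounds sitting at the limit, the most reasonable expectation is that compound 4 also shows no step beyond the scatter, and the expected step from compound 3 to compound 4 in this assay is a step that the limit leaves unreadable from compound 3 to compound 4. The estimate for compound 4 in this assay is 40000 nM, within a range from 15000 nM to 120000 nM.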

Compound 4, half-maximal cytotoxic concentration: > 25000 nM
Compound 4: only a limit was reported (the forecaster's own chance of this, stated with the estimate: 80%); the middle value is on the limit's open side.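

Compound 3 and compound 4 each give only a limit in this assay, so no step can be read for swapping the methoxy for a hydroxy. The compounds shown leave open at what concentration any of them becomes toxic to these cells, because all stand at one value: the limit of > 25000 nM in this assay, at which 4 of the 4 values shown sit.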